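The compounds below may be only part of what the source reports. "The series", "measured", "known", "first", "only" and "open" are said of these compounds alone.

The compounds share one core, seen in compound 1 `Nc1cc(N)c2nc(-c3ccccc3)c(Oc3ccc(Cl)c(Cl)c3)nc2c1`, and are compared in a functional assay on NCI-H522 cells (Homo sapiens) for inhibition, read by sulforhodamine B assay, with a stated time of 48 h; a lower number here means a stronger inhibitor of growth, a higher number a weaker inhibitor of growth. Compound 1 gives 33900 nM. Compound 2 `Nc1cc(N)c2nc(-c3ccccc3)c(NCc3ccc(F)cc3)nc2c1` carries a (4-fluorobenzyl)amino group in place of the 3,4-dichlorophenoxy group of compound 1. In this assay compound 2 reaches only a limit of the assay, < 100000 nM, not a number. Compound 3 `COc1ccc(Sc2nc3cc(N)cc(N)c3nc2-c2ccccc2)cc1` carries a (4-methoxyphenyl)sulfanyl group at that place. In this assay compound 3 likewise returns a limit rather than a number, < 100000 nM, so where it stands among the three cannot be fixed. The steps between the measured compounds, a step that the limit leaves unreadable from compound 1 to compound 2, a step that the limit leaves unreadable from compound 1 to compound 3 and a step that the two limits leave unreadable from compound 2 to compound 3, are all unreadable, since the limit of < 100000 nM in this assay, at which 2 of the 3 values shown sit, covers two of the three values.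

Compound 4 `Nc1cc(N)c2nc(-c3ccccc3)c(Sc3ccc(Cl)c(Cl)c3)nc2c1` differs from compound 3 by 3,4-dichlorophenyl in place of 4-methoxyphenyl on a sulfur. Among the compounds with values here, no measured step mirrors this exchange on a sulfur. The closest anchor is compound 1, which carries the 3,4-dichlorophenyl group on an oxygen and gives 33900 nM. On that basis alone compound 4 is expected to give about 40000 nM, within 10000 nM to 100000 nM. The implied step that the limit leaves unreadable from compound 3 to compound 4 is an estimate only, as compound 3 rests on a limit.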

Compound 4, concentration for total growth inhibition: 33900 nM
Beside the measured number, compound 4's estimate is 1.2-fold (0.07 log units) above it, and the stated range covers the measured number.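

Within the data shown here, replacing the 3,4-dichlorophenoxy group with the (3,4-dichlorophenyl)sulfanyl group on the same aromatic carbon of the shared core gives no change at the digits printed from compound 1 to compound 4 (within the scatter) in this assay, the first step at this position that can be read. With the 3,4-dichlorophenyl group held constant, the oxygen and sulfur links therefore cannot be told apart in this read-out, and compound 4 gives a number on the sulfur link, where the earlier sulfur compound gave none: compound 3, which carries 4-methoxyphenyl on that sulfur, returns only a limit of the assay, < 100000 nM. The steps to compound 4 from compound 2 and from compound 3 cannot be read, for a reason that lies in the assay values themselves: the limit of < 100000 nM in this assay, at which 2 of the 4 values shown sit.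

The compounds shown leave open how far compound 3 lies from compound 4, and so whether exchanging 4-methoxyphenyl for 3,4-dichlorophenyl on the sulfur changes the value at all. They also leave open what a (3,4-dichlorophenyl)amino group at this place, or a carboxylic acid or a longer chain on the same aromatic carbon, would give in this assay.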